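Working notes: from compound 3 to compound 4

The source may hold more compounds than are shown below. What is called first, only, known or untested is meant among the compounds shown, and "the series" means these compounds.

Measured in a functional assay on MV4-11 cells (Homo sapiens) for inhibition, read by resazurin assay, with a stated time of 72 h; a lower number here means a stronger inhibitor of growth, a higher number a weaker inhibitor of growth:
- compound 1 `O=C1NCCC12CCN(c1c(Cl)cncc1-c1ccsc1)CC2`: 190 nM
- compound 2 `O=Cc1ccc(-c2cncc(Cl)c2N2CCC3(CCNC3=O)CC2)o1`: 5190 nM
- compound 3 `Cn1cc(-c2cncc(Cl)c2N2CCC3(CCNC3=O)CC2)cn1`: 5530 nM

Compound 3 sits at the weak end of these three numbers, and it cannot be separated from its nearest neighbour: a 1.1-fold higher number from compound 2 to compound 3 (0.03 log units; within the scatter). The gap to the remaining compound is large: a 29-fold higher number from compound 1 to compound 3 (1.46 log units; beyond the scatter). The formylfuran compound shows a similar gap: a 27-fold higher number from compound 1 to compound 2 (1.44 log units; beyond the scatter).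

The next compound, compound 4 `O=C1NCCC12CCN(c1c(Cl)cncc1-c1cnn(C(F)F)c1)CC2`, carries difluoromethyl in place of methyl on an aromatic nitrogen. For the measured compounds named here, no measured step changes this nitrogen substituent, so the data hold no direct precedent. The nearest evidence is the set of three steps above, all of which replace the whole group on an aromatic carbon. Two of them are large, so this assay does respond to that group. Those steps exchange entire rings, however, whereas here the 1-methyl-1H-pyrazol-4-yl ring stays in place. A step of that size is therefore not expected. The reference point is compound 3 at 5530 nM, and only a small shift towards a lower number is expected: a 1.8-fold lower number from compound 3 to compound 4 (0.27 log units; within the scatter). For compound 4 the estimated value is 3000 nM, with an expected range of 900 nM to 8000 nM.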

Compound 4, concentration for 50% growth inhibition: 6140 nM
Estimate against measurement, compound 4: 2.0-fold (0.31 log units) below; the range from low to high includes it.
By their numbers in this assay, from the lowest: compound 1; then compounds 2, 3 and 4 (each within the scatter of the next).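

In this assay, this is the only step shown that alters the substituent on the aromatic nitrogen of the five-membered aromatic ring, and it gives no measurable separation between difluoromethyl and methyl (a 1.1-fold higher number from compound 3 to compound 4 (0.05 log units; within the scatter)). The 1-(difluoromethyl)-1H-pyrazol-4-yl group also cannot be separated from 5-formylfuran-2-yl (a 1.2-fold higher number from compound 2 to compound 4 (0.07 log units; within the scatter)), yet it stands far from thiophen-3-yl (a 32-fold higher number from compound 1 to compound 4 (1.51 log units; beyond the scatter)), so compounds 2, 3 and 4 form one cluster and only compound 1 stands apart from it. No supporting measurement accompanies these numbers to account for the cluster or for the gap to compound 1.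

Still open, on these data alone, is whether this nitrogen responds to anything other than these two small groups, such as a longer chain like propyl, an amine or a carboxylic acid carried on an ethyl chain. Also open, as far as these compounds go, is whether the gap to compound 1 at 190 nM belongs to thiophen-3-yl specifically, or whether rings such as phenyl or thiophen-2-yl on the same aromatic carbon would fall on its side of the gap.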